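Shortening the isoxazole substituent in a nucleoside series

The compounds below may be only part of what the source reports. "The series", "measured", "known", "first", "only" and "open" are said of these compounds alone.

Measured so far:
Compound 1 `CCCCc1ccc(-c2cc(-c3cn([C@H]4C[C@H](OC(C)=O)[C@@H](COC(C)=O)O4)c(=O)[nH]c3=O)on2)cc1` gives 72.2%.
Compound 2 `CC(=O)OC[C@H]1O[C@@H](n2cc(-c3cn(Cc4ccc(C(C)(C)C)cc4)nn3)c(=O)[nH]c2=O)C[C@@H]1OC(C)=O` gives 105%.
Compound 3 `O=c1[nH]c(=O)n([C@H]2C[C@H](O)[C@@H](CO)O2)cc1-c1cn(Cc2ccccc2)nn1` gives 103%.

All three compounds were tested in a functional assay on MDA-MB-231 cells (Homo sapiens) for cytotoxicity, read by sulforhodamine B assay, tested at 10 uM; on this read-out higher numbers stand for more inhibition at the one concentration tested (going by the name of the read-out) and lower numbers for less inhibition. Compound 1 stands lowest of the three numbers. Its nearest neighbour is compound 3, whose number lies above it by more than the scatter, and compound 2 lies further above, also beyond the scatter. Compounds 2 and 3 are within the scatter of each other, so no order between them is claimed.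

The next compound, compound 4 `CC(=O)OC[C@H]1O[C@@H](n2cc(-c3cc(C)no3)c(=O)[nH]c2=O)C[C@@H]1OC(C)=O`, has not yet been measured in this assay. It differs from compound 1 in one place: methyl in place of 4-butylphenyl on an aromatic carbon. Going by the values given here, no pair of measured compounds shares this change, so no measured step shows its size.

Among the compounds with values here, compound 1, which carries the 4-butylphenyl, already gives the lowest number of the three, and nothing among the measured compounds points to a gain from a smaller group on that ring. The step from compound 1 to compound 4 is expected to be downward, probably beyond the scatter: a number 27.2 percentage points lower from compound 1 to compound 4 (beyond the scatter). Compound 4 is estimated at 45%, with a range from 10% to 80%.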

Compound 4, a percentage reported as inhibition, at one concentration (the size of the read-out at that concentration, not a potency): 106%
The estimate for compound 4 lay 61 percentage points below the measured number, outside the stated range (above it).
By their numbers in this assay, from the lowest: compound 1; then compounds 3, 2 and 4 (each within the scatter of the next).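

In this assay, putting methyl in place of 4-butylphenyl on this aromatic carbon of the five-membered ring, next to the ring nitrogen, gives a number 33.8 percentage points higher from compound 1 to compound 4 (beyond the scatter), a large step. This shows that the 4-butylphenyl, with its 10 heavy atoms and its six-membered aromatic ring, is not needed at this position to keep the read-out up, and that on the core of compound 1 the single carbon of the methyl goes with more inhibition, not less. Nothing at hand accounts for the size or the direction of this step.

Only the two ends of the change are shown, so it stays open whether the rise comes from losing the butyl chain or the phenyl ring, which an unsubstituted phenyl or an ethyl on the same carbon would help to separate. As far as these compounds go, it is also open what an amine or a carboxylic acid would give at this carbon, and how far apart compound 1 and compound 4 would lie across a range of concentrations rather than at the single one tested.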